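Fixing One Stereocentre: What Happens to the Number?

This account rests on a few compounds, and the source may have more. Where it says the series, first, only, none or still open, it means among the compounds named here.

Going by the values given here, in a functional assay on A-375 cells (Homo sapiens) for activation, with a stated time of 3 days (a higher number here means that more compound is needed for the effect, a lower number that less compound is needed), compound 2 (`O=C(Nc1ccc(-c2ccc[nH]2)cc1)C1CCCN(Cc2ccc(F)c(F)c2)C1`) gives 720 nM, the lower of the two numbers measured so far. The other, compound 1 (`O=C(Nc1ccc(-c2cscn2)cc1)[C@@H]1CCCN(Cc2ccc(F)c(F)c2)C1`), gives 4000 nM, and this gap lies beyond the scatter. Compound 3 (`O=C(Nc1ccc(-c2ccc[nH]2)cc1)[C@@H]1CCCN(Cc2ccc(F)c(F)c2)C1`) has the same atoms and bonds as compound 2: the two compounds have the same atoms and bonds; at least one stereo element is drawn with a configuration in one of them and without one in the other: 1 of 1 stereo elements differ; a stereocentre at a saturated ring carbon is drawn without a configuration in compound 2 and R in compound 3. A compound drawn without a configuration may contain both mirror-image forms, so a single form could in principle shift the number either way. Among the compounds with values here, no measured pair here shows the effect of such a change. A small step toward a lower number, near the edge of the scatter, is therefore expected, though a step the other way cannot be excluded. The estimated step is a 1.6-fold lower number from compound 2 to compound 3 (0.20 log units; within the scatter). For compound 3 the expected value is 450 nM, within an estimated range of 180 nM to 1300 nM.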

Compound 3, half-maximal effective concentration: 19900 nM
Estimate against measurement, compound 3: 44-fold (1.65 log units) below; the whole stated range lies below it.
By their numbers in this assay, from the lowest: compound 2; then compound 1; then compound 3.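

At this saturated ring carbon, the drawn configuration matters a great deal in this assay: the R form gives a 28-fold higher number from compound 2 to compound 3 (1.44 log units; beyond the scatter), so most of the activity of compound 2 cannot come from the R form alone. The only thing that can account for so large a step is a difference in stereochemistry: the fact that one of compounds 2 and 3 is drawn with a defined configuration and the other without, at the place where they differ. With the R configuration drawn in both, 1H-pyrrol-2-yl in place of 1,3-thiazol-4-yl gives a 5.0-fold higher number from compound 1 to compound 3 (0.70 log units; beyond the scatter), so the 1H-pyrrol-2-yl group does not by itself bring a lower number.

Going by these compounds, whether the S form accounts for the number of compound 2 stays open, since no compound here is drawn as S. Also open is how an amine or a carboxylic acid in place of the 1H-pyrrol-2-yl group would fare with either configuration.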